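The compounds below may be only part of what the source reports. "The series", "measured", "known", "first", "only" and "open" are said of these compounds alone.

In an ADME assay on HEK293 cells (Homo sapiens) for cytotoxicity, read by MTT assay, with a stated time of 72 h (a higher number here means a weaker inhibitor, a lower number a stronger inhibitor), compound 1 `COCOc1cc(C2=C(c3cc(OC)c(OC)c(OC)c3)C(=O)CC2O[SiH2]C(C)(C)C)ccc1OC` reaches only a limit, > 100 ug/mL, so its cytotoxicity is known as a limit and not as a number. Compound 2 `COc1ccc(C2=C(c3cc(OC)c(OC)c(OC)c3)C(=O)CC2C)cc1C(=O)O` likewise gives only a limit in this assay, > 100 ug/mL. Going by the values given here, both of these results sit at the limit of > 100 ug/mL in this assay, at which 2 of the 2 values shown sit, and because both stand at the same limit, no step between measured compounds can be drawn from them. Compound 3 `COc1cc(C2=C(c3cc(C)c(OC)c(C)c3)C(O[SiH2]C(C)(C)C)CC2=O)cc(OC)c1OC` has not yet been tested in this assay. It differs from compound 1 in one place: 4-methoxy-3,5-dimethylphenyl in place of 4-methoxy-3-(methoxymethoxy)phenyl on a double-bonded ring carbon, with the 4-methoxy-3,5-dimethylphenyl entering in place of the 4-methoxy-3-(methoxymethoxy)phenyl on a double-bonded ring carbon of the shared core. Given that compound 1 sits at > 100 ug/mL, the step that the limit leaves unreadable from compound 1 to compound 3 is expected to be none beyond the usual scatter. Compound 3 is therefore estimated at 120 ug/mL, within a range of 50 ug/mL to 300 ug/mL, and most likely to be returned again as a limit rather than a number.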

Compound 3, half-maximal inhibitory concentration: 29 ug/mL
Beside the measured number, compound 3's estimate is 4.1-fold (0.62 log units) above it, and the stated range ends above it.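

In this assay, replacing 4-methoxy-3-(methoxymethoxy)phenyl with 4-methoxy-3,5-dimethylphenyl on a double-bonded ring carbon gives an at least 3.4-fold lower number from compound 1 to compound 3 (0.53 log units; beyond the scatter). This shows that the group at this place can move the read-out from the assay's limit to a real number, and the change in cytotoxicity lies beyond the usual scatter of repeat measurements. The earlier compounds shown here could not show this, as they gave no number to compare: the limit of > 100 ug/mL in this assay, at which 2 of the 3 values shown sit.

Since the swap changes the whole aryl group at once, these compounds cannot separate the effect of the two methyl groups entering from that of the methoxymethoxy group leaving. Going by these compounds, it also remains open how an amine or a free hydroxyl on this aromatic ring would read in the same test.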